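A few compounds are considered here, and "the series" means these few. Any claim that something is new, unique, unknown or untested is made for them only; others in the source may bear on it.

Notes on the series in an ADME assay on NCI-H226 cells (Homo sapiens) for cytotoxicity, read by MTT assay; a lower number here means a stronger inhibitor, a higher number a weaker inhibitor.

Compound 1 `C/C(COc1cccc2ccccc12)=N\O` gives only a limit of the assay, > 50000 nM. Compound 2 `O/N=C(\COc1cccc2ccccc12)c1ccccc1` gives 47100 nM. Compound 3 `O/N=C(\COc1cccc2ccccc12)c1ccc(Br)cc1` likewise gives only a limit of the assay, > 50000 nM. Among the measured compounds shown here, the single measured step, bromo in place of hydrogen on an aromatic carbon, is an at least 1.0-fold higher number from compound 2 to compound 3 (0.02 log units; that floor lies within the scatter); its floor lies within the scatter, and because compound 3 sits at the limit of > 50000 nM in this assay, at which 2 of the 3 values shown sit, the two values show no change that can be read as real.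

Where compound 3 stands, then: it holds a limit and not a number, the same limit that the value of compound 1 shows, so no ranking among the three compounds is possible on these data.

Compound 4 `O/N=C(\COc1cccc2ccccc12)c1ccc(-c2ccccc2)cc1` differs from compound 3 by phenyl in place of bromo on an aromatic carbon. For the measured compounds named here, the only measured step that bears on this site is the one from compound 2 to compound 3, which was at most the floor, and no measured step places phenyl anywhere, so nothing indicates a move beyond the scatter. Compound 4 is therefore expected to give again a limit rather than a number, with an estimate of 50000 nM and a range of 20000 nM to 100000 nM. The expected step is a number no higher from compound 3 to compound 4 (the limit leaves the size open).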

Compound 4, half-maximal inhibitory concentration: > 50000 nM
Compound 4: no number, only a limit (the forecaster's own chance of this, stated with the estimate: 70%); the middle value sits exactly at the limit.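

Phenyl with its 6 heavy atoms in place of bromo with its 1 heavy atom, on the same aromatic carbon, still brings no number out of this assay at this position. Compound 4 therefore adds a six-membered aromatic ring of carbon only at this site without giving a readable change. Among the compounds shown here, its one readable step is an at least 1.0-fold higher number from compound 2 to compound 4 (0.02 log units; that floor lies within the scatter) and so shows nothing that can be taken as real, the same reading as for bromo; the step between the two limits cannot be read.

From the compounds shown here alone, whether an amine or a carboxylic acid on this aromatic carbon would give a number rather than a limit stays open. So does any ranking of hydrogen, bromo and phenyl at this site, because the values stand at one ceiling: the limit of > 50000 nM in this assay, at which 3 of the 4 values shown sit.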